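Methoxy in Place of Bromo on the Aryl Ring

The compounds below may be only part of what the source reports. "The series", "measured", "known", "first", "only" and "open" are said of these compounds alone.

Measured so far in a functional assay on MCF7 cells (Homo sapiens) for cytotoxicity, read by MTT assay, with a stated time of 96 h; a lower number here means a stronger inhibitor, a higher number a weaker inhibitor:
Compound 1, `Cc1cc2c(c(=O)o1)C(c1c[nH]c3ccc(Br)cc13)C(C#N)=C(N)O2`, gives 5000 nM.
Compound 2, `Cc1cc2c(c(=O)o1)C(c1ccc(Br)cc1)C(C#N)=C(N)O2`, gives 35000 nM.
Compound 3, `Cc1cc2c(c(=O)o1)C(c1ccco1)C(C#N)=C(N)O2`, gives 27000 nM.

Compound 2 holds the highest of the three numbers. Its nearest neighbour is compound 3, whose value lies within the scatter of its own; its furthest is compound 1, whose number is lower by a margin beyond the scatter.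

Compound 4, `COc1ccc(C2C(C#N)=C(N)Oc3cc(C)oc(=O)c32)cc1`, differs from compound 2 in one place: methoxy in place of bromo on an aromatic carbon. Going by the values given here, only one measured step touches the group on the saturated ring carbon, namely a 1.3-fold lower number from compound 2 to compound 3 (0.11 log units; within the scatter), in which the whole ring was exchanged and the number still stayed within the scatter. Among the compounds with values here, no measured pair changes a single substituent on the six-membered aromatic ring of carbon only, so nothing bears directly on this replacement. With that in hand, no shift beyond the scatter in this assay is expected, in either direction.

Compound 4 is therefore estimated to give 30000 nM, in a range from 12000 nM to 80000 nM. The expected step from compound 2 is a 1.2-fold lower number from compound 2 to compound 4 (0.07 log units; within the scatter).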

Compound 4, half-maximal inhibitory concentration: 57000 nM
Estimate against measurement, compound 4: 1.9-fold (0.28 log units) below; low and high end bracket the measured number.
By their numbers in this assay, from the lowest: compound 1; then compounds 3, 2 and 4 (each within the scatter of the next, the first and the last beyond it).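

In this assay, going by these compounds alone, the step from bromo to methoxy gives a 1.6-fold higher number from compound 2 to compound 4 (0.21 log units; within the scatter), the first reading of a single substituent changed on a six-membered aromatic ring of carbon only, and it stays within the scatter. The entering methoxy adds a hydrogen-bond acceptor and one more heavy atom, and neither addition carries the number beyond the scatter at this carbon, para to a large group. No measurement at hand explains the direction or the size of this step.

As far as these compounds go, whether an amine or a carboxylic acid on this aromatic carbon would give a step beyond the scatter remains open. Also open, from the compounds shown here alone, is whether exchanging bromo for methoxy on compound 1 would give a step of similar size.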